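The compounds below may be only part of what the source reports. "The series", "measured", "known", "first", "only" and "open" are said of these compounds alone.

Of the compounds shown here, two have been measured in a physicochemical assay for lipophilicity; a higher number here means a more lipophilic compound, a lower number a more polar compound. Compound 1 `N=C(N)Nc1cccc(C(=O)NNC(=O)NC(CC(=O)O)c2cccc3ccccc23)c1` gives 1.7 in this assay, and compound 2 `O=C(O)CC(CC(=O)NNC(=O)CCCCNc1ccccn1)c1ccccc1` gives 2.07. Compound 2 thus stands highest of the two numbers; its nearest neighbour is compound 1, whose value lies lower by a margin beyond the scatter. Going by the values given here, no measured pair differs in a single place, so no measured step bears directly on the change considered next.

Compound 3 `O=C(O)CC(CC(=O)NNC(=O)CCCCNc1ccccn1)c1ccc(-c2ccccc2)cc1` has not yet been measured. It differs from compound 2 in one place: phenyl in place of hydrogen on an aromatic carbon, para to a large group. An upward step in this assay is expected, well beyond the scatter. The expected step is a number 1.73 log units higher from compound 2 to compound 3 (beyond the scatter). Compound 3 is accordingly estimated at 3.8, within a range from 3.2 to 4.4.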

Compound 3, partition coefficient: 3.74
Estimate against measurement, compound 3: 0.06 log units above; the measured number falls inside the stated range.
By their numbers in this assay, from the lowest: compound 1; then compound 2; then compound 3.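

In this assay, phenyl in place of hydrogen on an aromatic carbon, para to a large group, reads as a number 1.67 log units higher from compound 2 to compound 3 (beyond the scatter), the first single-place step available in this series. This position on compound 2 therefore accepts a whole six-membered aromatic ring of carbon only, and the change moves the number by a large margin rather than a marginal one. No measurement at hand bears on what lies behind the size of this step.

The compounds shown leave open whether a smaller substituent at this position, such as methyl or chlorine, or a pyridyl ring in place of phenyl, would give a step of similar size. On these data alone, it also remains open whether phenyl on another carbon of that ring, or on the core of compound 1, would move the number as far.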